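A few compounds are considered here, and "the series" means these few. Any claim that something is new, unique, unknown or untested is made for them only; others in the source may bear on it.

Compound 3 `COc1ccc(CN(C(=O)Nc2ccc(C#N)cc2)n2cnnc2)cc1OC` sits at a limit in a functional assay on MCF7 cells (Homo sapiens) for cytotoxicity, read by MTT assay, with a stated time of 48 h (a higher number here means a weaker inhibitor, a lower number a stronger inhibitor), returning > 50000 nM. Compound 1 `COc1ccc(CN(C(=O)Nc2ccc(Cl)cc2)n2cnnc2)cc1OC` likewise returns only a limit in this assay, > 50000 nM. Among the compounds with values here, compound 2 `COc1ccc(CN(C(=O)Nc2ccc(F)c(Cl)c2)n2cnnc2)cc1OC` is the single member with a measured number in this assay, giving 30100 nM. Of the recorded steps, an at least 1.6-fold lower number from compound 1 to compound 2 (0.22 log units; that floor lies within the scatter) and an at least 1.6-fold higher number from compound 2 to compound 3 (0.22 log units; that floor lies within the scatter) are mere floors, and a step that the two limits leave unreadable from compound 1 to compound 3 cannot be read at all, since two of the three values sit at the limit of > 50000 nM in this assay, at which 2 of the 3 values shown sit. Compound 4 `COc1ccc(CN(C(=O)Nc2ccc(C)cc2)n2cnnc2)cc1OC` arises through (methyl in place of cyano on an aromatic carbon). Within the data shown here, no measured step probes a change of this kind, so the expected step is a number no higher from compound 3 to compound 4 (the limit leaves the size open), nothing clearer than the scatter. Compound 4 is therefore estimated at 50000 nM, within 15000 nM to 150000 nM, most probably again as a limit.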

Compound 4, half-maximal inhibitory concentration: > 50000 nM
Compound 4: no number, only a limit (the forecaster's own chance of this, stated with the estimate: 65%); the middle value sits exactly at the limit.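

Methyl in place of cyano on this aromatic carbon changes nothing that can be seen: in this assay compound 4 also returns only a limit, > 50000 nM. Methyl thus joins chloro and cyano at the limit, and the 3-chloro-4-fluorophenyl of compound 2 remains the only exception, with an at least 1.6-fold higher number from compound 2 to compound 4 (0.22 log units; that floor lies within the scatter) as the one readable step. The steps from compound 1 and from compound 3 to compound 4 cannot be read: the limit of > 50000 nM in this assay, at which 3 of the 4 values shown sit.

As far as these compounds go, whether an amine or a carboxylic acid on this aromatic carbon would return a number stays open. So does any ranking of compound 1, compound 3 and compound 4.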